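Moving the Methyl Group: From Compound 2 to Compound 3

This account rests on a few compounds, and the source may have more. Where it says the series, first, only, none or still open, it means among the compounds named here.

Measured so far:
Compound 1, `Cc1ccsc1C(=O)/C=C/c1ccc(N2CCCCC2)cc1`: 26400 nM
Compound 2, `Cc1csc(C(=O)/C=C/c2ccc(N3CCCCC3)cc2)c1`: 68800 nM

In an ADME assay on PBMC cells (Homo sapiens) for cytotoxicity, with a stated time of 5 days (on this read-out lower numbers stand for stronger inhibition and higher numbers for weaker inhibition), compound 2 gives 68800 nM, the higher of the two numbers obtained so far. Its nearest neighbour is compound 1, which gives 26400 nM, and the step of a 2.6-fold higher number from compound 1 to compound 2 (0.42 log units; beyond the scatter) lies beyond the scatter. Compound 3, `Cc1ccc(C(=O)/C=C/c2ccc(N3CCCCC3)cc2)s1`, has not yet been measured. It differs from compound 2 in one place: 5-methylthiophen-2-yl in place of 4-methylthiophen-2-yl on a carbonyl carbon. Among the measured compounds shown here, the only measured step that bears on this change is the earlier shift of the methyl group on the same ring, a 2.6-fold higher number from compound 1 to compound 2 (0.42 log units; beyond the scatter), which was modest but clearly beyond the scatter. That step shows that the position of the methyl on this ring can move the number by a modest amount, but it offers no guide to the direction of a second shift. The step from compound 2 to compound 3 is therefore expected to be small, a 1.4-fold lower number from compound 2 to compound 3 (0.14 log units; within the scatter), and either direction remains possible. Compound 3 is estimated to give 50000 nM in this assay, within a range from 20000 nM to 125000 nM.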

Compound 3, half-maximal inhibitory concentration: 77800 nM
Beside the measured number, compound 3's estimate is 1.6-fold (0.19 log units) below it; measured number inside the range.
By their numbers in this assay, from the lowest: compound 1; then compounds 2 and 3 (each within the scatter of the next).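

In this assay, the change from 4-methylthiophen-2-yl to 5-methylthiophen-2-yl on the carbonyl carbon gives a 1.1-fold higher number from compound 2 to compound 3 (0.05 log units; within the scatter), so this read-out does not separate these two groups. The 3-methylthiophen-2-yl group of compound 1 now stands apart from both: alongside the earlier 2.6-fold higher number from compound 1 to compound 2 (0.42 log units; beyond the scatter), there is a 2.9-fold higher number from compound 1 to compound 3 (0.47 log units; beyond the scatter), and compound 1 therefore has the lowest number of the three, with neither of the other two compounds going against this split. Nothing available explains why the 3-methylthiophen-2-yl group stands apart from the other two groups.

The compounds shown leave open whether this split depends on the methyl group itself or would also appear with an ethyl group, a longer chain, a methoxy group or an amine on the same ring. They also leave open how any of these methylthiophen-2-yl groups would compare with an unsubstituted thiophen-2-yl group on the carbonyl carbon, and whether the same split would hold with a different group in place of the rest of the shared core.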